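Swapping phenylsulfonyl on a compound that sits at a limit

The source may report more compounds than this note shows. Statements on the series, on what has been measured and on what is new or still open speak of the compounds shown alone.

In a functional assay on cells (Homo sapiens) for inhibition, read by MTT assay, with a stated time of 72 h (on this read-out lower numbers stand for stronger inhibition and higher numbers for weaker inhibition), compound 3 `O=C(O)Cn1ncc2c(Nc3ccc(NS(=O)(=O)c4ccccc4)cc3)ncnc21` reads > 100 ug/mL, which is a limit and not a number. Compound 1 `CCOC(=O)Cn1ncc2c(Nc3ccc(NS(=O)(=O)c4ccccc4)cc3)ncnc21`, with ethyl on the oxygen next to the carbonyl group, also gives only a limit, > 100 ug/mL. Compound 2 `CC(=O)Nc1ccc(Nc2ncnc3c2cnn3CC(=O)O)cc1`, with acetyl on the nitrogen on an aromatic ring, gives a limit too, > 64 ug/mL.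

Compound 4 `O=C(O)Cn1ncc2c(Nc3ccc(NC(=O)CCl)cc3)ncnc21` differs from compound 3 in one place: (chloromethyl)carbonyl in place of phenylsulfonyl on a nitrogen on an aromatic ring In words, (chloromethyl)carbonyl comes in place of phenylsulfonyl on a nitrogen on an aromatic ring.

The closest guide is a step that the two limits leave unreadable from compound 2 to compound 3, which changes that same nitrogen. The other is a step that the two limits leave unreadable from compound 1 to compound 3, which changes a different place. Neither has a readable size, so the data set no firm size or direction for this change.

The expected change is an at least 1.4-fold lower number from compound 3 to compound 4 (0.15 log units; that floor lies within the scatter), a modest shift toward stronger inhibition that remains a tentative estimate. For compound 4 the estimate is 70 ug/mL, with an expected range from 20 ug/mL to 200 ug/mL.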

Compound 4, half-maximal inhibitory concentration: > 100 ug/mL
Compound 4: a limit, no number; the forecaster's own chance of this, stated with the estimate: 60%; middle value at least 1.4-fold (0.15 log units) from the limit.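

Compound 4 gives only a limit, as do compound 2 and compound 3, so neither step to compound 4 can be read. As far as these compounds go, with all four compounds at limits, how strongly any of them inhibits, and whether the group on that nitrogen matters, stays open.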